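Hexyloxy in place of pyrrolidinyl: cytotoxicity outlook

The compounds below may be only part of what the source reports. "The series", "measured", "known", "first", "only" and "open" are said of these compounds alone.

Compound 3 `Nc1nc(N2CCCC2)c2ncn(/C=C3/CC3(CO)CO)c2n1` is the reference point for this step. In an ADME assay on CCRF-HSB-2 cells (Homo sapiens) for cytotoxicity, with a stated time of 7 days (on this read-out higher numbers stand for lower toxicity in this test and lower numbers for higher toxicity in this test), compound 3 returns only a limit, > 20000 nM. Compound 1 `C=CCOc1nc(N)nc2c1ncn2/C=C1/CC1(CO)CO` likewise returns a limit in this assay, > 20000 nM. Compound 2 `CCOc1nc(N)nc2c1ncn2/C=C1/CC1(CO)CO` also returns a limit in this assay, > 20000 nM. On the numbers shown compound 3 therefore stands level with the other two, all of them sitting at the limit of > 20000 nM in this assay, at which 3 of the 3 values shown sit. The measured steps are a step that the two limits leave unreadable from compound 1 to compound 2, a step that the two limits leave unreadable from compound 1 to compound 3 and a step that the two limits leave unreadable from compound 2 to compound 3; none of them has a readable size, so none gives a direction or a magnitude to carry forward.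

Compound 4 `CCCCCCOc1nc(N)nc2c1ncn2/C=C1/CC1(CO)CO` differs from compound 3 as follows: hexyloxy in place of pyrrolidin-1-yl on an aromatic carbon. The change sits on the same aromatic carbon that the measured steps varied, and every one of those variations ended at the limit, so no step beyond the scatter is expected; the expected step is a step that the limit leaves unreadable from compound 3 to compound 4. Compound 4 is accordingly expected to give about 30000 nM in this assay, within 9000 nM to 100000 nM, most probably reported once more as a limit.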

Compound 4, half-maximal cytotoxic concentration: > 20000 nM
Compound 4 was reported as a limit; the forecaster's own chance of this, stated with the estimate: 85%; the middle value does not contradict the limit.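

In this assay compound 4 gives > 20000 nM, a limit and not a number, so no step from compound 1, compound 2 or compound 3 to compound 4 can be read: the limit of > 20000 nM in this assay, at which 4 of the 4 values shown sit.

The compounds shown leave open how large any difference between these groups on the aromatic carbon is, and in which direction it runs.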